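Two Chemokine Receptor Ligands and a Proposed Third

The source may hold more compounds than are shown below. What is called first, only, known or untested is meant among the compounds shown, and "the series" means these compounds.

Compound 1: `Cc1ccccc1C(=O)NCc1ccc(CNS(=O)(=O)c2ccc(Cl)cc2)cc1` gives 1 nM in an assay on MDA-MB-231 cells for displacement of a labelled ligand from C-X-C chemokine receptor type 4 (Homo sapiens), read by fluorescence and microscopy, with stated times of 10 min and 30 min; a lower number here means that less compound is needed, a higher number that more compound is needed for the effect.
Compound 2: `COc1ccccc1C(=O)NCc1ccc(CNS(=O)(=O)c2ccccc2F)cc1` gives 1 nM in this assay.

Compound 1 and compound 2 share one core and differ in two places at once, yet in this assay compound 2 stands level with compound 1 at the digits reported, the two values lying within the usual scatter of each other. Neither can be called the stronger.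

The next step leads from compound 2 to compound 3, `COc1ccccc1C(=O)NCc1ccc(CNS(=O)(=O)c2ccc(Cl)cc2)cc1`, which has not been measured. The change is 4-chlorophenyl in place of 2-fluorophenyl on a sulfonyl sulfur. Compound 3 thus carries the sulfonyl part of compound 1 together with the amide part of compound 2, both of which already appear in a measured compound: in this assay compound 1 gives 1 nM and compound 2 gives 1 nM. Since both measured compounds sit at the same level, the step of no change at the digits printed from compound 2 to compound 3 (within the scatter) is expected to be no larger than the scatter, in either direction. Compound 3 is therefore estimated at 1 nM in this assay, with a likely range from 0.5 nM to 2 nM.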

Compound 3, effective concentration (reported as EC, without a stated level of effect): 1000 nM
The estimate for compound 3 lay 1000-fold (3.00 log units) below the measured number; the whole stated range lies below it.
By their numbers in this assay, from the lowest: compounds 1 and 2 (each within the scatter of the next); then compound 3.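

With the amide part of compound 2 kept, 4-chlorophenyl in place of 2-fluorophenyl on a sulfonyl sulfur gives a 1000-fold higher number from compound 2 to compound 3 (3.00 log units; beyond the scatter) in this assay, so this position is far from indifferent to the change. With the 4-chlorophenyl group kept, methoxy in place of methyl on an aromatic carbon gives a 1000-fold higher number from compound 1 to compound 3 (3.00 log units; beyond the scatter), which shows that each single change is large when taken alone, something compounds 1 and 2, which differ in two places at once, could not show. Nothing in the data shown accounts for the size of these steps.

As far as these compounds go, what a 4-fluorophenyl or a 2-chlorophenyl group on the sulfonyl sulfur would give stays open, and with it whether the halogen or its place carries the step. Also open, from the compounds shown here alone, is how an ethoxy group or a plain hydrogen in place of methoxy on the aromatic carbon would read alongside the 4-chlorophenyl group.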